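From Diethylamino to Amino: Expecting a Modest Rise

This account rests on a few compounds, and the source may have more. Where it says the series, first, only, none or still open, it means among the compounds named here.

In an ADME assay on L6 cells (Rattus norvegicus) for cytotoxicity, read by resazurin assay, with a stated time of 72 h (a higher number here means a weaker inhibitor, a lower number a stronger inhibitor), compound 1 `CCOc1ccc(C(=O)NC(=O)c2ccccc2O)cc1` gives 17 ug/mL, compound 2 `O=C(NC(=O)c1ccccc1O)c1ccc(OCc2ccccc2)cc1` gives 64 ug/mL, and compound 3 `CCN(CC)c1ccc(C(=O)NC(=O)c2ccccc2O)cc1` gives 8.2 ug/mL, the lowest of the three numbers. Compound 4 `Nc1ccc(C(=O)NC(=O)c2ccccc2O)cc1` has not been measured. It carries amino in place of diethylamino on an aromatic carbon, para to a large group (amino in place of diethylamino on an aromatic carbon). Within the data shown here, no measured compound carries amino, so the guidance is indirect. Two modest steps end at compound 3, and both lowered the number: a 2.1-fold lower number from compound 1 to compound 3 (0.32 log units; beyond the scatter) and a 7.8-fold lower number from compound 2 to compound 3 (0.89 log units; beyond the scatter). Leaving diethylamino may therefore give back a similar amount, so the expected step is a 2.7-fold higher number from compound 3 to compound 4 (0.43 log units; beyond the scatter). For compound 4 the estimated value is 22 ug/mL, with an expected range of 7 ug/mL to 70 ug/mL.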

Compound 4, half-maximal inhibitory concentration: 39 ug/mL
The estimate for compound 4 lay 1.8-fold (0.25 log units) below the measured number; the measured number falls inside the stated range.
By their numbers in this assay, from the lowest: compound 3; then compound 1; then compounds 4 and 2 (each within the scatter of the next).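

In this assay, a nitrogen on the ring does not by itself bring the number down: the step of a 4.8-fold higher number from compound 3 to compound 4 (0.68 log units; beyond the scatter) shows that the low number of compound 3 depends on diethylamino rather than on amino. Amino also compares unfavourably with ethoxy, with a 2.3-fold higher number from compound 1 to compound 4 (0.36 log units; beyond the scatter) as the step, while the step of a 1.6-fold lower number from compound 2 to compound 4 (0.22 log units; within the scatter) leaves amino and benzyloxy apart by no more than the usual scatter. No measurement here explains these differences. The compounds shown also leave open whether ethylamino, with a single ethyl group on the nitrogen, would give a number nearer to that of amino or of diethylamino.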